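The source may report more compounds than this note shows. Statements on the series, on what has been measured and on what is new or still open speak of the compounds shown alone.

Values in a functional assay on LoVo cells (Homo sapiens) for inhibition, read by MTT assay, with a stated time of 72 h; on this read-out higher numbers stand for weaker inhibition and lower numbers for stronger inhibition:
- compound 1 `CCCNC(=O)c1ccc(Oc2nc(-c3c(C)noc3C)cnc2N)cc1`: 17500 nM
- compound 2 `Cc1noc(C)c1-c1cnc(N)c(Oc2ccc(C(=O)Nc3ccccc3Cl)cc2)n1`: > 100000 nM

The value of compound 2 is a limit of the assay, not a number (the limit of > 100000 nM in this assay, at which 1 of the 2 values shown sits). Going by the values given here, of the two compounds, compound 2 is the weaker inhibitor, the single measured step being an at least 5.7-fold higher number from compound 1 to compound 2 (0.75 log units; beyond the scatter). Compound 3 `Cc1noc(C)c1-c1cnc(N)c(Oc2ccc(C(=O)Nc3cc(Cl)ccn3)cc2)n1` differs from compound 2 by 4-chloropyridin-2-yl in place of 2-chlorophenyl on an amide-type nitrogen. Among the compounds with values here, no measured step covers an exchange of this kind at the amide nitrogen, and the series already sits at the limit after an at least 5.7-fold higher number from compound 1 to compound 2 (0.75 log units; beyond the scatter), so no step beyond the scatter is expected in this assay. Compound 3 is estimated at 100000 nM, range 30000 nM to 300000 nM, meaning a number no higher from compound 2 to compound 3 (the limit leaves the size open).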

Compound 3, half-maximal inhibitory concentration: > 100000 nM
Compound 3: only a limit was reported (the forecaster's own chance of this, stated with the estimate: 60%); the middle value sits exactly at the limit.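

In this assay compound 3 gives > 100000 nM, a limit and not a number, so a ring with a hetero atom on the amide nitrogen, 4-chloropyridin-2-yl, brings back no readable value. Exchange of propyl for this group reads as an at least 5.7-fold higher number from compound 1 to compound 3 (0.75 log units; beyond the scatter). The steps involving both limits cannot be read, because the two aromatic compounds sit together at the ceiling: the limit of > 100000 nM in this assay, at which 2 of the 3 values shown sit.

Open, from the compounds shown here alone, is how far compound 2 and compound 3 lie past that limit. Also open, going by these compounds, is whether a longer chain such as butyl, or an aminoethyl group, on the amide nitrogen gives a lower number than compound 1 at 17500 nM.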